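The source may hold more compounds than are shown below. What is called first, only, known or untested is meant among the compounds shown, and "the series" means these compounds.

Working notes on the spiro-fused diaminotriazine series. Among the measured compounds shown here, the one compound with a number is compound 1 `NC1=NC2(CCOCC2)N(OCCCOc2ccc(F)cc2)C(N)=N1`, which in an assay on isolated protein for inhibition of Dihydrofolate reductase (Homo sapiens), read by spectrophotometry, using NADPH, with stated times of 5 s and 6 min (on this read-out lower numbers stand for stronger inhibition and higher numbers for weaker inhibition), gives 46.6 nM; it therefore stands alone as the only reference point. Compound 2 `NC1=NC2(CCSCC2)N(OCCCOc2ccccc2Cl)C(N)=N1` has no result in this assay, the entry reading "not determined" (no result reported), and the same holds for compound 3 `NC1=NC2(CCSCC2)N(OCCCOc2cccc(Br)c2)C(N)=N1`, with "not determined" (no result reported). For the measured compounds named here, no step between two measured compounds is thus available.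

The next compound, compound 4 `NC1=NC2(CCOCC2)N(OCCCOc2ccc(Br)cc2)C(N)=N1`, differs from compound 1 in one place: bromo in place of fluoro on an aromatic carbon. Going by the values given here, with no comparable step in hand, the step from compound 1 to compound 4 in this assay is expected to be small, at most a modest move toward stronger inhibition, and likely within the scatter, giving a 1.3-fold lower number from compound 1 to compound 4 (0.12 log units; within the scatter). Compound 4 is accordingly estimated at 35 nM, with a range of 15 nM to 100 nM.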

Compound 4, half-maximal inhibitory concentration: 32.5 nM
Beside the measured number, compound 4's estimate is 1.1-fold (0.03 log units) above it; the range from low to high includes it.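

In this assay, bromo in place of fluoro on an aromatic carbon para to a large group gives a 1.4-fold lower number from compound 1 to compound 4 (0.16 log units; within the scatter) and so the two halogens cannot be told apart at this position. Among the compounds shown here, this is the only readable step so far, and it rests on a single pair of compounds. Nothing available bears on this result.

From the compounds shown here alone, whether an amine, a methoxy group or a carboxylic acid at this position would read the same remains open. So does the effect of a longer chain in the linker.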